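Propylamino for propoxy on the shared core

The source may hold more compounds than are shown below. What is called first, only, known or untested is meant among the compounds shown, and "the series" means these compounds.

Measured so far:
compound 1 `Cc1nc(N)c2nc(O)n(Cc3ccccc3)c2n1`: 3 mg/kg
compound 2 `CCCOc1nc(N)c2nc(O)n(Cc3ccccc3)c2n1`: 0.3 mg/kg

In a functional assay on the whole organism for activation, with Mus musculus as the target (a lower number here means that less compound is needed, a higher number that more compound is needed for the effect), compound 2 stands at the lowest of the two numbers, with compound 1 the nearest. Going by the values given here, the one measured step is a 10-fold lower number from compound 1 to compound 2 (1.00 log units; beyond the scatter), a change of the same ring position that is now altered again.

Compound 3 `CCCNc1nc(N)c2nc(O)n(Cc3ccccc3)c2n1` is not yet measured. It differs from compound 2 by propylamino in place of propoxy on an aromatic carbon. Among the compounds with values here, no measured step exchanges propoxy for propylamino, so the step above bears only in that it shows the position tolerates a chain of the same length with a lower number than methyl. With a chain of equal length kept, no step beyond the scatter is expected in this assay, though a somewhat higher number cannot be excluded. Compound 3 is therefore expected at about 0.5 mg/kg, with a range from 0.1 mg/kg to 3 mg/kg. The expected step is a 1.7-fold higher number from compound 2 to compound 3 (0.22 log units; within the scatter).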

Compound 3, minimum effective dose: 1 mg/kg
Compound 3: middle estimate off by 2.0-fold (0.30 log units), on the low side, and the stated range covers the measured number.
By their numbers in this assay, from the lowest: compound 2; then compound 3; then compound 1.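

In this assay, the atom joining the chain to the aromatic carbon between two ring nitrogen atoms proves to matter even with the chain kept: there is a 3.3-fold higher number from compound 2 to compound 3 (0.52 log units; beyond the scatter) on exchanging propoxy for propylamino, a change that also brings in a hydrogen-bond donor. Propylamino still compares well with methyl, with a 3.0-fold lower number from compound 1 to compound 3 (0.48 log units; beyond the scatter) in this change, so a lower number than that of compound 1 is not confined to propoxy among the groups at hand. No measurement available here accounts for the difference between propoxy and propylamino.

Open, going by these compounds, is whether dimethylamino, which has no amine hydrogen, or propylthio would follow propoxy or propylamino. Also open, on these data alone, is how butoxy, butylamino or a still longer chain would fall relative to these propyl-length groups.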